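The source may hold more compounds than are shown below. What is called first, only, known or untested is meant among the compounds shown, and "the series" means these compounds.

Compound 1, `CNC(=O)c1sc(N2CC3CC2(CNC(=O)c2c[nH]c4ncc(C(F)(F)F)cc24)C3)nc1C(F)(F)F`, gives > 100000 nM in an assay on isolated protein for inhibition of tyrosine-protein kinase receptor TYRO3 (Homo sapiens), read by LC-MS, with stated times of 30 min and 180 min; a lower number here means a stronger inhibitor, a higher number a weaker inhibitor; that figure is a limit of the assay, not a number.
Compound 2, `CNC(=O)c1sc(N2CC3CC2(CNC(=O)c2c[nH]c4ncccc24)C3)nc1C(F)(F)F`, gives 2000 nM in this assay.
Compound 3, `CN(Cc1ccc2nccn2c1)c1nnc(-c2ncc(C(F)(F)F)cc2Cl)o1`, gives > 100000 nM in this assay; this too is a limit rather than a number.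

Going by the values given here, compound 2 thus holds the only real number in the set, while the other two sit at the limit of > 100000 nM in this assay, at which 2 of the 3 values shown sit. Among the compounds with values here, the one measured step that matters here runs between compound 1 and compound 2, where hydrogen replaces trifluoromethyl on an aromatic carbon, and it shows an at least 50-fold lower number from compound 1 to compound 2 (1.69 log units; beyond the scatter). Compound 4, `CNC(=O)c1sc(N2CC3CC2(CNC(=O)c2c[nH]c4ncc(C)cc24)C3)nc1C(F)(F)F`, carries methyl in place of hydrogen on an aromatic carbon, at the very place where compound 1 bore its trifluoromethyl. Within the data shown here, no measurement yet tells how methyl behaves at that spot, only that a group there can cost a great deal. The expected step is a 5.0-fold higher number from compound 2 to compound 4 (0.70 log units; beyond the scatter), towards a weaker inhibitor, because compound 1 showed an at least 50-fold lower number from compound 1 to compound 2 (1.69 log units; beyond the scatter) in the opposite direction when its group was removed. Compound 4 is therefore estimated at 10000 nM, with a range from 2500 nM to 60000 nM.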

Compound 4, half-maximal inhibitory concentration in the tyrosine-protein kinase receptor TYRO3 assay: 1000 nM
Compound 4: the middle estimate sits 10-fold (1.00 log units) above what was measured; the measured number lies below the stated range.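

In the tyrosine-protein kinase receptor TYRO3 assay, a small group on this aromatic carbon need not cost anything: methyl in place of hydrogen gives a 2.0-fold lower number from compound 2 to compound 4 (0.30 log units; within the scatter), so the two compounds cannot be told apart. The large loss seen earlier therefore belongs to trifluoromethyl at this place rather than to any group there, since methyl in place of trifluoromethyl gives an at least 100-fold lower number from compound 1 to compound 4 (2.00 log units; beyond the scatter). As far as these compounds go, the value of compound 1 behind that step is a limit of the assay, not a number, so the true size of the step remains unknown.

In a physicochemical assay for solubility (a higher number here means a more soluble compound, a lower number a less soluble compound), compound 2 gives < 1600 nM, which is a limit of the assay, not a number. In the physicochemical assay, compound 4 gives < 1600 nM, which is also a limit of the assay, not a number. From the compounds shown here alone, in the physicochemical assay, the step from hydrogen to methyl cannot be read, as both values are limits: the limit of < 1600 nM in the physicochemical assay, at which 2 of the 2 values shown sit. It also remains open how a longer chain, an amine or a carboxylic acid on this aromatic carbon would fare in the tyrosine-protein kinase receptor TYRO3 assay.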